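Adding one methoxy to compound 2

The source may report more compounds than this note shows. Statements on the series, on what has been measured and on what is new or still open speak of the compounds shown alone.

Compound 1 (`COc1ccc(/C=C/C(=O)C(=Cc2cc(Br)c(O)c(OC)c2)C(=O)/C=C/c2ccc(OC)cc2OC)c(OC)c1`) gives 1780 nM
Compound 2 (`COc1cc(OC)c(/C=C/C(=O)C(=Cc2ccc(O)c(OC)c2)C(=O)/C=C/c2c(OC)cc(OC)cc2OC)c(OC)c1`) gives 1350 nM

In a functional assay on CNE-2 cells (Homo sapiens) for antiproliferative activity, read by sulforhodamine B assay, with a stated time of 48 h (a lower number here means a stronger inhibitor, a higher number a weaker inhibitor), compound 2 gives 1350 nM and sits within the usual scatter of compound 1, so the two cannot be told apart, even though their structures differ in several places.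

Compound 3 (`COc1cc(OC)c(/C=C/C(=O)C(=Cc2cc(OC)c(O)c(OC)c2)C(=O)/C=C/c2c(OC)cc(OC)cc2OC)c(OC)c1`) has not been measured yet. It differs from compound 2 in one place (methoxy in place of hydrogen on an aromatic carbon): methoxy in place of hydrogen on an aromatic carbon, ortho to a hydroxy group, so that 4-hydroxy-3-methoxyphenyl becomes 4-hydroxy-3,5-dimethoxyphenyl.

Among the compounds with values here, no measured pair shows this change on its own, so the expectation rests on thin evidence. Compound 1, at 1780 nM in the same test, stays within the scatter of compound 2 despite differing from it in more than one place. For this single addition, no shift beyond the scatter is therefore expected in this assay, in either direction. The estimated 1.1-fold lower number from compound 2 to compound 3 (0.03 log units; within the scatter) is small. For compound 3 the estimated value is 1250 nM with an expected range from 550 nM to 2900 nM in this test.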

Compound 3, half-maximal inhibitory concentration: 680 nM
The estimate for compound 3 lay 1.8-fold (0.26 log units) above the measured number, and the stated range covers the measured number.
By their numbers in this assay, from the lowest: compounds 3, 2 and 1 (each within the scatter of the next, the first and the last beyond it).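

Within the data shown here, compound 2 and compound 3 form the first pair here that differs in one place only, so this change can be read on its own, free of the other differences that blur the earlier comparison. In this assay, turning 4-hydroxy-3-methoxyphenyl into 4-hydroxy-3,5-dimethoxyphenyl gives a 2.0-fold lower number from compound 2 to compound 3 (0.30 log units; within the scatter) with the rest of the structure left as it is, which means that a methoxy in place of hydrogen at this spot, ortho to a hydroxy group, is tolerated but cannot be claimed as a real gain from this single pair. Nothing measured here bears on how the added methoxy might act on the cells.

What the compounds shown leave open is how far this position accepts other groups, for instance an amine, a carboxylic acid or a longer chain such as an ethoxy group in place of the same hydrogen. Among these compounds, also open is whether the same addition would give a similar result with the other parts of the molecule changed, since only one pair speaks to it.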